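The source may report more compounds than this note shows. Statements on the series, on what has been measured and on what is new or still open speak of the compounds shown alone.

Measured so far in a functional assay on HeLa cells (Homo sapiens) for cytotoxicity, read by MTT assay, with a stated time of 72 h; on this read-out lower numbers stand for stronger inhibition and higher numbers for weaker inhibition:
- compound 1 `COc1ccc(OC)c(/C=C/C(=O)Nc2cc3c(Nc4ccc(F)c(Cl)c4)ncnc3cc2OC)c1`: "not determined" (no result reported)
- compound 2 `COc1ccc(/C=C/C(=O)Nc2cc3c(Nc4ccc(F)c(Cl)c4)ncnc3cc2O[C@H]2CCOC2)c(OC)c1`: 26500 nM
- compound 3 `COc1ccc(OC)c(/C=C/C(=O)Nc2cc3c(Nc4ccc(F)c(Cl)c4)ncnc3cc2O[C@H]2CCOC2)c1`: 26800 nM

For the measured compounds named here, only two numbers can therefore be compared in this assay, and compound 3, at 26800 nM, stands level with compound 2 within the scatter.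

The next compound is compound 4 `COc1cc(/C=C/C(=O)Nc2cc3c(Nc4ccc(F)c(Cl)c4)ncnc3cc2O[C@H]2CCOC2)cc(OC)c1`, which has the same atoms as compound 3, joined differently: 3,5-dimethoxyphenyl in place of 2,5-dimethoxyphenyl on a double-bonded chain carbon bound to a double-bonded chain carbon. It carries 3,5-dimethoxyphenyl in place of 2,5-dimethoxyphenyl, with the rest of the structure unchanged.

Going by the values given here, one measured step bears on this change, since it also alters the dimethoxyphenyl group at the same place: a 1.0-fold higher number from compound 2 to compound 3 (0.00 log units; within the scatter). That step lies within the scatter, so no shift beyond the scatter is expected here, in either direction. Among the compounds with values here, a single step is thin evidence, however, and no measured compound yet carries the 3,5-dimethoxyphenyl group. The expected step is a 1.1-fold lower number from compound 3 to compound 4 (0.03 log units; within the scatter). The estimated value for compound 4 is 25000 nM, with an expected range of 11000 nM to 50000 nM.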

Compound 4, half-maximal inhibitory concentration: 34300 nM
The estimate for compound 4 lay 1.4-fold (0.14 log units) below the measured number; the measured number falls inside the stated range.
By their numbers in this assay, from the lowest: compounds 2, 3 and 4 (each within the scatter of the next).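

In this assay, the 3,5-dimethoxyphenyl group adds a third arrangement of the two methoxy groups at this place on the chain, and it gives a 1.3-fold higher number from compound 3 to compound 4 (0.11 log units; within the scatter) and a 1.3-fold higher number from compound 2 to compound 4 (0.11 log units; within the scatter). Where the earlier compounds offered a single comparison, compounds 2, 3 and 4 now give three, and all three lie within the scatter. Across these three compounds, then, the arrangement of the two methoxy groups does not separate the numbers, and no compound among them goes against this. No measurement at hand offers an explanation for this result.

From the compounds shown here alone, it remains open whether an amine or a carboxylic acid in place of a methoxy group on this phenyl ring, or a longer chain in place of the ethenyl link, would shift the number. Whether any change at this place reaches beyond the scatter also stays unanswered.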